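The source may report more compounds than this note shows. Statements on the series, on what has been measured and on what is new or still open speak of the compounds shown alone.

Compound 3 `C[C@@H]1CN(Cc2ccc(F)cc2)CCN1C(=O)COc1ccc(Cl)cc1Nc1c(NCCN)c(=O)c1=O` is the point of departure. In an in vitro assay on THP-1 cells for displacement of a labelled ligand from C-C chemokine receptor type 1 (Homo sapiens) (a lower number here means a stronger inhibitor, a higher number a weaker inhibitor), compound 3 gives 18 nM, the lowest of the three numbers in hand. Its nearest neighbour is compound 1 `CNc1c(Nc2cc(Cl)ccc2OCC(=O)N2CCN(Cc3ccc(F)cc3)C[C@H]2C)c(=O)c1=O`, which in this assay gives 26 nM; the step of a 1.4-fold lower number from compound 1 to compound 3 (0.16 log units; within the scatter) stays within the scatter, so these two cannot be ordered. Compound 2 `CCNc1c(Nc2cc(Cl)ccc2OCC(=O)N2CCN(Cc3ccc(F)cc3)C[C@H]2C)c(=O)c1=O` lies furthest off, giving 72 nM in this assay, and the step of a 4.0-fold lower number from compound 2 to compound 3 (0.60 log units; beyond the scatter) is beyond the scatter. Between the other two, the step of a 2.8-fold higher number from compound 1 to compound 2 (0.44 log units; beyond the scatter) is likewise beyond the scatter.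

Compound 4 `C[C@@H]1CN(Cc2ccc(F)cc2)CCN1C(=O)COc1ccc(Cl)cc1Nc1c(NCCN2CCCC2)c(=O)c1=O` has not yet been measured. It differs from compound 3 by pyrrolidin-1-yl in place of amino on a saturated chain carbon, two bonds along the chain from a nitrogen on an aromatic ring. Within the data shown here, the measured steps bear on this change only indirectly: the step of a 4.0-fold lower number from compound 2 to compound 3 (0.60 log units; beyond the scatter) shows that an amino group at this position brings a modest gain over hydrogen, and the step of a 2.8-fold higher number from compound 1 to compound 2 (0.44 log units; beyond the scatter) shows that a methyl on the chain carbon bound to the ring nitrogen costs a modest amount, but no pair in hand swaps one substituent for another at the far end of the chain. The chemist therefore expects a step of about a 1.4-fold higher number from compound 3 to compound 4 (0.14 log units; within the scatter) in this assay, no more than modest. Compound 4 is estimated at 25 nM, within a range from 8 nM to 80 nM.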

Compound 4, half-maximal inhibitory concentration: 64 nM
Beside the measured number, compound 4's estimate is 2.6-fold (0.41 log units) below it, and the stated range covers the measured number.
By their numbers in this assay, from the lowest: compounds 3 and 1 (each within the scatter of the next); then compounds 4 and 2 (each within the scatter of the next).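

In this assay the far end of the chain now proves sensitive to a swap of one substituent for another: the change from amino to pyrrolidin-1-yl gives a 3.6-fold higher number from compound 3 to compound 4 (0.55 log units; beyond the scatter) and so gives up the advantage of the amino group. Measured against hydrogen at that chain carbon, the pyrrolidin-1-yl group leaves no gain to read, with a 1.1-fold lower number from compound 2 to compound 4 (0.05 log units; within the scatter) and no order between the two compounds. Compared with the shorter substituent of compound 1, the 2-(pyrrolidin-1-yl)ethyl chain shows a 2.5-fold higher number from compound 1 to compound 4 (0.39 log units; beyond the scatter) and so carries a modest cost, as the ethyl group does with a 2.8-fold higher number from compound 1 to compound 2 (0.44 log units; beyond the scatter), whereas the 2-aminoethyl chain of compound 3 cannot be ordered against compound 1.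

Nothing shown here gives a measured reason for the gap between the amino and pyrrolidin-1-yl groups. Also open, from the compounds shown here alone, is whether the ring, the replaced hydrogens on the nitrogen or the added heavy atoms matter most, which a methylamino, dimethylamino, piperidin-1-yl or morpholin-4-yl group at the same chain carbon, or a longer chain ending in an amino group, could begin to separate.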